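Swapping the Aryl Group on a Thromboxane Receptor Blocker

The source may hold more compounds than are shown below. What is called first, only, known or untested is meant among the compounds shown, and "the series" means these compounds.

Four sulfonamide acids share one core. Compound 1 `O=C(O)COCCCCC1=CCC[C@@H]1NS(=O)(=O)c1ccc(Cl)c(Cl)c1` gives 1900 nM in a functional assay on a cell-free system (plasma) for inhibition of thromboxane A2 receptor (Homo sapiens), read by turbidimetry; a lower number here means a stronger inhibitor, a higher number a weaker inhibitor; compound 2 `Cc1ccc(S(=O)(=O)N[C@H]2CCC=C2CCCCOCC(=O)O)cc1` gives 1900 nM, level with compound 1 and together with it the highest of the three numbers; compound 3 `Cc1ccc(S(=O)(=O)N[C@H]2CCC=C2C/C=C\CCCC(=O)O)cc1` gives 250 nM. The step of no change at the digits printed from compound 1 to compound 2 (within the scatter) changes only the group on the sulfonyl sulfur, whereas a 7.6-fold lower number from compound 2 to compound 3 (0.88 log units; beyond the scatter) changes the acid-bearing chain. Compound 4 `O=C(O)COCCCCC1=CCC[C@@H]1NS(=O)(=O)c1ccc(F)cc1F` differs from compound 2 in the same place as the first step: 2,4-difluorophenyl in place of 4-methylphenyl on a sulfonyl sulfur. Within the data shown here, only the step from compound 1 to compound 2 bears on this change, and it showed nothing beyond the scatter, so for no change at the digits printed from compound 2 to compound 4 (within the scatter) no change beyond the scatter is expected. Compound 4 is therefore estimated at 1900 nM, between 800 nM and 4500 nM.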

Compound 4, half-maximal inhibitory concentration: 1800 nM
Beside the measured number, compound 4's estimate is 1.1-fold (0.02 log units) above it; the range from low to high includes it.
By their numbers in this assay, from the lowest: compound 3; then compounds 4, 1 and 2 (each within the scatter of the next).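

In this assay there is a 1.1-fold lower number from compound 2 to compound 4 (0.02 log units; within the scatter), and there is a 1.1-fold lower number from compound 1 to compound 4 (0.02 log units; within the scatter). Alongside 4-methylphenyl and 3,4-dichlorophenyl, 2,4-difluorophenyl is now a third group on the sulfonyl sulfur that leaves the number level, so on the 3-(carboxymethoxy)propyl chain these three groups cannot be told apart. No supporting data bear on why the numbers stay level.

Still open, from the compounds shown here alone, is whether these three groups would also stay level on the 5-carboxypent-1-en-1-yl chain of compound 3. Also open, going by these compounds, is what a butyl chain, or a phenyl ring carrying an amine, would do on the sulfonyl sulfur.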